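Acylsulfonamide and Sulfonylhydrazide Amides Probed for Receptor Binding

The source may hold more compounds than are shown below. What is called first, only, known or untested is meant among the compounds shown, and "the series" means these compounds.

The series consists of three amides built on a shared core. Compound 1 `CCCCS(=O)(=O)NC(=O)[C@@H](NC(=O)c1cccc(Cn2ccnc2)c1)[C@@H](C)CC` carries a butylsulfonyl group on its terminal amide nitrogen, but in an assay on HEK293 cells for displacement of a labelled ligand from Type-2 angiotensin II receptor (Homo sapiens), tested at 1 uM (on this read-out lower numbers stand for a weaker effect and higher numbers for a stronger effect at the one concentration tested), compound 1 is recorded as "not determined" (no result reported), so no number is available for it. For the measured compounds named here, compound 2 `CC[C@H](C)[C@H](NC(=O)c1cccc(Cn2ccnc2)c1)C(=O)NNS(=O)(=O)c1ccc(C)cc1` is therefore the only member with a number in this assay, and that number is low: in this assay compound 2 gives 4%.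

Compound 3 `CC[C@H](C)[C@H](NC(=O)c1cccc(Cn2ccnc2)c1)C(=O)NC#N` differs from compound 2 in a single place (cyano in place of ((4-methylphenyl)sulfonyl)amino on an amide-type nitrogen). Going by the values given here, no step between two measured compounds exists for this change, so its size cannot be read from the data. Given that compound 2 shows 4%, a read-out near the bottom of the scale, the expected step in this assay from compound 2 to compound 3 is small and within the usual scatter, with no clear direction. Compound 3 is accordingly expected to give 5% in this assay, with a plausible range from -5% to 20%, an estimated step of a number 1 percentage points higher from compound 2 to compound 3 (within the scatter).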

Compound 3, a percentage reported as inhibition, at one concentration (the size of the read-out at that concentration, not a potency): 6%
Compound 3: middle estimate off by 1 percentage points, on the low side; the range from low to high includes it.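

In this assay, placing cyano instead of ((4-methylphenyl)sulfonyl)amino on the amide-type nitrogen gives a number 2 percentage points higher from compound 2 to compound 3 (within the scatter). The group that leaves has 11 heavy atoms and a six-membered aromatic ring of carbon only, while the cyano that enters has 2 heavy atoms and no ring, yet this large change in the group leaves the two compounds indistinguishable on this read-out, and both remain near the bottom of the scale at the one concentration tested. Nothing measured bears on why this is so.

Any step involving compound 1 cannot be read, so the butylsulfonyl group on the terminal amide nitrogen gives no further comparison at this position. As far as these compounds go, it remains open whether any group on this amide-type nitrogen, such as a carboxylic acid or a longer chain, would bring the read-out clearly away from the bottom of the scale, since two compounds this low cannot show how much the position matters.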